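A few compounds are considered here, and "the series" means these few. Any claim that something is new, unique, unknown or untested is made for them only; others in the source may bear on it.

Measured compounds

- compound 1, `C/N=C(/S)C1(c2cccnc2)CCCC/C1=C\C#N` — in a functional assay (aorta) with Rattus norvegicus as the target (a lower number here means a stronger inhibitor, a higher number a weaker inhibitor), compound 1 gives 10000 nM
- compound 2, `C/N=C(/S)C1(c2cccnc2)CCCC/C1=C\CO` — in this assay compound 2 gives 10000 nM
- compound 3, `C/N=C(/S)C1(c2cccnc2)CCCC/C1=C\COc1ccccc1` — in this assay compound 3 gives 65 nM

Compound 3 holds the lowest number of the three, and its distance to the others is beyond the scatter on both sides: a 150-fold lower number from compound 1 to compound 3 (2.19 log units; beyond the scatter) and a 150-fold lower number from compound 2 to compound 3 (2.19 log units; beyond the scatter). Compound 1 and compound 2 lie together, no change at the digits printed from compound 1 to compound 2 (within the scatter), so the whole spread of the series comes from the phenoxymethyl arm.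

Compound 4, `C/N=C(/S)C1(c2cccnc2)CCCC/C1=C\COc1ccc([N+](=O)[O-])cc1`, keeps that arm and differs from compound 3 only at its far end: nitro in place of hydrogen on an aromatic carbon.

For the measured compounds named here, of the measured steps, only the one from compound 2 to compound 3 touches the same region, and it is large; yet it concerns putting the phenyl in place at all, not changing a substituent on it. Going by the values given here, no measured pair varies a group on that aromatic ring, so there is no direct precedent for the size of this step. Given that the arm itself carries the whole gain, a substituent on it is expected to move the number only modestly, in either direction, and most likely within the scatter: a 1.1-fold higher number from compound 3 to compound 4 (0.03 log units; within the scatter). Compound 4 is therefore estimated at 70 nM in this assay, with a plausible range from 20 nM to 250 nM.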

Compound 4, concentration for 90% inhibition: 100 nM
Beside the measured number, compound 4's estimate is 1.4-fold (0.15 log units) below it, and the stated range covers the measured number.
By their numbers in this assay, from the lowest: compounds 3 and 4 (each within the scatter of the next); then compounds 1 and 2 (each within the scatter of the next).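

In this assay the far end of the phenoxymethyl arm accepts a substituent at this place: nitro on an aromatic carbon, para to a large group, gives a 1.5-fold higher number from compound 3 to compound 4 (0.19 log units; within the scatter) and so leaves compound 3 and compound 4 without an order. The gain carried by the arm survives this change, as the comparison with the free hydroxymethyl compound shows with a 100-fold lower number from compound 2 to compound 4 (2.00 log units; beyond the scatter) and the 4-nitrophenyl group stands clear of hydrogen on that oxygen, just as the unsubstituted phenyl does. No supporting data bear on the cause of either step.

A single substituent at a single place leaves open whether other groups on this ring, such as an amine, a carboxylic acid or a methoxy group, would stay as close to compound 3 as nitro does, and whether nitro at another ring carbon would behave the same way. Also open, going by these compounds, is whether the ether oxygen of the arm is needed, a question that a benzyl group or a longer chain in place of phenoxymethyl would bear on.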